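Shifting one methyl group: from compound 3 to compound 4

The compounds below may be only part of what the source reports. "The series", "measured", "known", "first", "only" and "open" are said of these compounds alone.

In an ADME assay on MT4 cells (Homo sapiens) for cytotoxicity, read by MTT assay, with a stated time of 5 days (on this read-out lower numbers stand for higher toxicity in this test and higher numbers for lower toxicity in this test), compound 1 `O=c1[nH]c2ccc(Cl)cc2n1S(=O)(=O)Cc1ccccc1Cl` gives 52000 nM, compound 2 `O=c1[nH]c2ccc(Cl)cc2n1S(=O)(=O)Cc1ccc(Cl)cc1` gives 77000 nM and compound 3 `Cc1ccccc1CS(=O)(=O)n1c(=O)[nH]c2ccc(Cl)cc21` gives 238000 nM. Compound 3 thus holds the highest number of the three, clear of both others. Compound 4 `Cc1cccc(CS(=O)(=O)n2c(=O)[nH]c3ccc(Cl)cc32)c1` is its isomer, described by 3-methylphenyl in place of 2-methylphenyl on a saturated chain carbon bound to a sulfonyl sulfur.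

Among the measured compounds shown here, the closest precedent is the only measured step that relocates a group on this phenyl ring without replacing it, a 1.5-fold higher number from compound 1 to compound 2 (0.17 log units; within the scatter), and that step stays within the scatter. The exchanges that bring in the methyl are larger, at a 4.6-fold higher number from compound 1 to compound 3 (0.66 log units; beyond the scatter) and a 3.1-fold higher number from compound 2 to compound 3 (0.49 log units; beyond the scatter), though the second also relocates the group. Compound 4 keeps the methyl, so it is expected to stay nearer compound 3 than the two chlorinated compounds. For the measured compounds named here, with only one methyl compound measured, the data cannot show how much the position matters.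

The expected change is a 1.4-fold lower number from compound 3 to compound 4 (0.15 log units; within the scatter), a slight drop that is not expected to exceed the scatter. For compound 4 the estimated value is 170000 nM, with an expected range from 80000 nM to 320000 nM.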

Compound 4, half-maximal cytotoxic concentration: 110000 nM
Compound 4: the middle estimate sits 1.5-fold (0.19 log units) above what was measured, within the range that was stated.
By their numbers in this assay, from the lowest: compounds 1, 2 and 4 (each within the scatter of the next, the first and the last beyond it); then compound 3.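

In this assay, relocating the methyl on the phenyl ring gives a 2.2-fold lower number from compound 3 to compound 4 (0.34 log units; beyond the scatter), whereas the one earlier relocation of a group on this ring, that of the chloro group, stayed within the scatter. Among these compounds, then, the top number of compound 3 belongs to 2-methylphenyl and not to the methyl group wherever it sits: with 3-methylphenyl the series shows a 1.4-fold higher number from compound 2 to compound 4 (0.15 log units; within the scatter), which is within the scatter, while a 2.1-fold higher number from compound 1 to compound 4 (0.33 log units; beyond the scatter) is still beyond it, so the methyl compound keeps a modest margin over only the 2-chlorophenyl compound. Nothing available explains why the two methyl isomers part in this way.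

The compounds shown leave open whether a larger or different group on this phenyl ring, such as an ethyl group, a methoxy group or an amine, would follow the pattern of 2-methylphenyl or that of 3-methylphenyl in this assay. They also leave open whether the margin held by compound 3 survives any change to the shared core, since every compound here carries that same core.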